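Shifting the Carboxylic Acid From Compound 3 to Compound 4

This account rests on a few compounds, and the source may have more. Where it says the series, first, only, none or still open, it means among the compounds named here.

Measured so far:
Compound 1, `CN(C)C(=O)c1cnc(C(=O)CCc2ccc(COc3ccccc3)cc2)o1`: 6.7 nM
Compound 2, `O=C(O)c1ccc(-c2cnc(CCCc3ccc(-c4ccccc4)cc3)o2)nc1`: 20000 nM
Compound 3, `O=C(O)c1ccc(-c2cnc(C(O)CCc3ccc(-c4ccccc4)cc3)o2)nc1`: 10000 nM

In an assay for inhibition of Fatty-acid amide hydrolase 1 (Rattus norvegicus) (on this read-out higher numbers stand for weaker inhibition and lower numbers for stronger inhibition), compound 3 stands second highest of the three numbers. Its nearest neighbour is compound 2, and the step of a 2.0-fold lower number from compound 2 to compound 3 (0.30 log units; within the scatter) lies within the scatter, while compound 1 sits far lower, well beyond the scatter.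

Compound 4, `O=C(O)c1cccc(-c2cnc(C(O)CCc3ccc(-c4ccccc4)cc3)o2)n1`, is not yet measured. It differs from compound 3 in one place: 6-carboxypyridin-2-yl in place of 5-carboxypyridin-2-yl on an aromatic carbon. Among the compounds with values here, no measured step moves the carboxylic acid around its ring; the only known step, a 2.0-fold lower number from compound 2 to compound 3 (0.30 log units; within the scatter), concerns a hydroxy group and is within the scatter. With nothing pointing either way, the step of no change at the digits printed from compound 3 to compound 4 (within the scatter) is expected to stay within the scatter. Compound 4 is therefore estimated at 10000 nM, with a range from 3000 nM to 30000 nM.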

Compound 4, inhibition constant: 1100 nM
The estimate for compound 4 lay 9.1-fold (0.96 log units) above the measured number; measured number below the stated range.
By their numbers in this assay, from the lowest: compound 1; then compound 4; then compounds 3 and 2 (each within the scatter of the next).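

In this assay, 6-carboxypyridin-2-yl in place of 5-carboxypyridin-2-yl gives a 9.1-fold lower number from compound 3 to compound 4 (0.96 log units; beyond the scatter), a step beyond the scatter. The two compounds have the same atoms, joined differently, so where the carboxylic acid sits on this ring changes the number even though the groups count the same, something the hydroxy step between compound 2 and compound 3 could not show. No available evidence explains this shift. From the compounds shown here alone, whether a methyl ester or a primary amide in place of the carboxylic acid would keep this gain remains open.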